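The source may report more compounds than this note shows. Statements on the series, on what has been measured and on what is new or still open speak of the compounds shown alone.

Working notes on the sulfonylurea series.

Compound 1 `CCCNC(=O)NS(=O)(=O)c1ccc(-n2nc(-c3ccccc3)ccc2=O)cc1` is the reference. In a functional assay on the whole organism (blood, strain Wistar albino) for inhibition, with Rattus norvegicus as the target, read by colorimetric assay, with stated times of 15 min and 90 min, at a dose of 20 mg/kg by the oral route (a higher number here means more inhibition at the dose given (going by the name of the read-out), a lower number less inhibition), compound 1 gives 77.2%. Compound 2 `CCCCNC(=O)NS(=O)(=O)c1ccc(-n2nc(-c3ccccc3)ccc2=O)cc1` carries methyl in place of hydrogen on a saturated chain carbon, three bonds along the chain from an amide-type nitrogen relative to compound 1; in this assay compound 2 gives 67.4%, so that a number 9.8 percentage points lower from compound 1 to compound 2 (within the scatter). Compound 3 `CCCNC(=O)NS(=O)(=O)c1ccc(-n2nc(-c3ccc(C)cc3)ccc2=O)cc1` differs from compound 1 by methyl in place of hydrogen on an aromatic carbon; in this assay compound 3 gives 80.5%, so that a number 3.3 percentage points higher from compound 1 to compound 3 (within the scatter). Compound 3 shows the highest number of the three, but its gap to compound 1 is within the scatter, and only its gap to compound 2 lies beyond it.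

Compound 4 `CCCCNC(=O)NS(=O)(=O)c1ccc(-n2nc(-c3ccc(C)cc3)ccc2=O)cc1` has not yet been measured. It differs from compound 3 by methyl in place of hydrogen on a saturated chain carbon, three bonds along the chain from an amide-type nitrogen, the same change that was made from compound 1 to compound 2. The place line is identical word for word in both cases; what differs between the two cores is methyl in place of hydrogen on an aromatic carbon.

From compound 3 to compound 4 a step of a number 9.5 percentage points lower from compound 3 to compound 4 (within the scatter) is expected, beside the earlier a number 9.8 percentage points lower from compound 1 to compound 2 (within the scatter); this rests on that one measured step, which itself lay within the scatter, so the direction is uncertain and a flat outcome is equally plausible. Because compound 3 gives 80.5%, compound 4 is estimated at 71%, with a range from 58% to 82%.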

Compound 4, a percentage reported as inhibition, in the whole organism at one dose (the size of the read-out at that dose, not a potency): 86.6%
For compound 4 the middle estimate is 15.6 percentage points below the measured one, outside the stated range (above it).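

In this assay, the chain change on the core carrying the aromatic methyl gives a number 6.1 percentage points higher from compound 3 to compound 4 (within the scatter), and the aromatic methyl on the butyl compounds gives a number 19.2 percentage points higher from compound 2 to compound 4 (beyond the scatter). The chain change does not carry from one core to the other as a fixed step, although each of its two steps alone lies within the scatter, so it is the gap between them that counts and not the sign of either one: the same change on two cores in this assay, a number 9.8 percentage points lower (within the scatter) from compound 1 to compound 2 and a number 6.1 percentage points higher (within the scatter) from compound 3 to compound 4, 15.9 percentage points apart, beyond the scatter of two such steps Read the other way round, the same four compounds give the same gap, which is therefore one finding and not a second one, and it shows neither a rule for cores or chains beyond compounds 1 to 4 nor any reason for the gap: the same change on two cores in this assay, a number 3.3 percentage points higher (within the scatter) from compound 1 to compound 3 and a number 19.2 percentage points higher (beyond the scatter) from compound 2 to compound 4, 15.9 percentage points apart, beyond the scatter of two such steps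

Left open is how a longer chain such as pentyl, or a ring such as cyclohexyl, in place of the butyl chain would behave on either core. Also open, on these data alone, is whether a chloro or methoxy group in place of the methyl on the aromatic carbon would give the same kind of gap, and whether the gap holds at any other dose.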